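Swapping iodo for bromo on a potent growth inhibitor

A few compounds are considered here, and "the series" means these few. Any claim that something is new, unique, unknown or untested is made for them only; others in the source may bear on it.

Compound 1 `Cc1cc(-c2nc3cc(F)c(F)cc3s2)ccc1N`: > 100000 nM (a limit)
Compound 2 `Cc1cc(-c2nc3ccc(F)cc3s2)ccc1N`: 34700 nM
Compound 3 `Nc1ccc(-c2nc3cc(F)ccc3s2)cc1I`: < 10 nM (a limit)

In a functional assay on HCC 2998 cells (Homo sapiens) for inhibition (a higher number here means a weaker inhibitor of growth, a lower number a stronger inhibitor of growth), compound 3 gives < 10 nM, which is a limit and not a number. That places compound 3 at the limit of < 10 nM in this assay, at which 1 of the 3 values shown sits. Compound 1 sits at the other extreme, at the limit of > 100000 nM in this assay, at which 1 of the 3 values shown sits.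

Compound 4 `Nc1ccc(-c2nc3cc(F)ccc3s2)cc1Br` carries bromo in place of iodo on an aromatic carbon, ortho to an amino group, and is otherwise the same as compound 3: bromo in place of iodo on an aromatic carbon.

Within the data shown here, only one measured step exists, an at least 2.8-fold lower number from compound 1 to compound 2 (0.45 log units; beyond the scatter), and it is hydrogen in place of fluoro, not one halogen exchanged for another. It shows that a single atom can move the number beyond the scatter, but it gives no size for this change. Among the measured compounds shown here, compound 2 and compound 3 differ in more than one place and form no single step.

The estimate therefore starts from compound 3 at < 10 nM, a limit, and leaves room for a rise. The expected change is a number no lower from compound 3 to compound 4 (the limit leaves the size open), most likely small. Compound 4 is estimated at 10 nM, with an expected range of 1 nM to 300 nM, and it may well be reported only as a limit.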

Compound 4, concentration for 50% growth inhibition: < 10 nM
Compound 4 ended at the assay's limit (the forecaster's own chance of this, stated with the estimate: 60%); the middle value sits exactly at the limit.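

In this assay compound 4 gives < 10 nM, which is a limit and not a number. Compound 3 also stands at a limit, < 10 nM, so the step between compound 3 and compound 4, bromo in place of iodo, cannot be read. The compounds shown leave open how far each lies beyond that limit, and so whether the exchange changes growth inhibition at all.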